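A fluorophenyl swap at a cytotoxicity limit

The compounds below may be only part of what the source reports. "The series", "measured", "known", "first", "only" and "open" are said of these compounds alone.

- compound 1 `C=C[C@@](C)(/C=C/c1ccc(O)cc1)CC/C=C/C#N` gives > 36600 nM
- compound 2 `C=C[C@@](C)(/C=C/c1ccc(O)cc1)CC/C=C(C)/C=C/C(=O)OCc1ccccc1` gives > 36600 nM
- compound 3 `C=C[C@@](C)(/C=C/c1ccc(O)c(/C=C/C(=O)c2ccccc2)c1)CCC=C(C)C` gives > 7410 nM

In an ADME assay on HEK293 cells (Homo sapiens) for cytotoxicity, with a stated time of 72 h (on this read-out higher numbers stand for an effect only at larger amounts of compound and lower numbers for an effect already at smaller amounts), compound 3 stands at > 7410 nM as a limit of the assay. Among the compounds with values here, compounds 1 and 2 also give only limits, and no measured step links any of the three. Compound 4 `C=C[C@@](C)(/C=C/c1ccc(O)c(/C=C/c2ccc(F)cc2)c1)CCC=C(C)C` differs from compound 3 by one change: 4-fluorophenyl in place of benzoyl on a double-bonded chain carbon bound to a double-bonded chain carbon and the group enters on a double-bonded chain carbon bound to a double-bonded chain carbon. Within the data shown here, with no measured step as a guide, no step beyond the scatter is expected in this assay in either direction. The estimated change is a step that the limit leaves unreadable from compound 3 to compound 4 and stays within that scatter. A limit may well be reported again. The expected value for compound 4 is 12000 nM within an estimated range of 4000 nM to 37000 nM as its two ends.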

Compound 4, half-maximal effective concentration: > 36600 nM
Compound 4 ended at the assay's limit (the forecaster's own chance of this, stated with the estimate: 75%); middle value at least 3.0-fold (0.48 log units) from the limit.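

In this assay compound 3 gives > 7410 nM, which is a limit. Compound 4 gives > 36600 nM, also a limit, so no step can be read between compound 3 and compound 4. The compounds shown leave open whether 4-fluorophenyl in place of benzoyl changes the half-maximal effective concentration in this assay at all.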